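A few compounds are considered here, and "the series" means these few. Any claim that something is new, unique, unknown or untested is made for them only; others in the source may bear on it.

Measured so far in a functional assay on MNK45 cells (Homo sapiens) for inhibition, read by MTT assay, with a stated time of 48 h; on this read-out lower numbers stand for stronger inhibition and higher numbers for weaker inhibition:
- compound 1 `Cc1ccc(NC(=S)NC(=O)c2ccc(OCc3ccc(C(F)(F)F)cc3)cc2)cc1-c1nc2ccccc2[nH]1`: 10200 nM
- compound 2 `Cc1ccc(NC(=O)NC(=O)c2ccc(OCc3cccc(Cl)c3)cc2)cc1-c1nc2ccccc2[nH]1`: 28000 nM

Compound 2 stands at the higher of the two numbers; compound 1 lies at a lower number, and the gap between the two is beyond the usual scatter. The two compounds differ in more than one place, so nothing is said here about which part of the difference carries that gap.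

The next compound is compound 3 `Cc1ccc(NC(=O)NC(=O)c2ccc(OCc3ccc(Cl)cc3Cl)cc2)cc1-c1nc2ccccc2[nH]1`, which differs from compound 2 in one place only:

2,4-dichlorophenyl in place of 3-chlorophenyl on a saturated chain carbon bound to an oxygen on an aromatic ring

For the measured compounds named here, no single-point step between measured compounds is available in this set, so there is nothing to lean on for the size or direction of this change. The expectation for the step from compound 2 to compound 3 is therefore a small one, a 1.4-fold lower number from compound 2 to compound 3 (0.15 log units; within the scatter), not beyond the scatter, with a slight lean toward a lower number.

On that basis compound 3 is estimated at 20000 nM in this assay, with a range from 7000 nM to 60000 nM.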

Compound 3, half-maximal inhibitory concentration: 2550 nM
For compound 3 the middle estimate is 7.8-fold (0.89 log units) above the measured one; measured number below the stated range.
By their numbers in this assay, from the lowest: compound 3; then compound 1; then compound 2.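

In this assay, for the compounds shown here, the group on a saturated chain carbon bound to an oxygen on an aromatic ring is the first place where a single change can be read, and 2,4-dichlorophenyl in place of 3-chlorophenyl gives an 11-fold lower number from compound 2 to compound 3 (1.04 log units; beyond the scatter), a large step beyond the usual scatter. The swap is small by count, with 8 heavy atoms replacing 7 and no hydrogen-bond donor, hydrogen-bond acceptor or net charge on either side, yet it shows that the read-out is highly responsive to the substitution on this ring. Chlorine number and chlorine placement both change in this one step, and no information on hand accounts for the size of the shift.

From the compounds shown here alone, a single step cannot separate those two contributions, and it remains open how an unsubstituted phenyl, a pyridine ring or a 2,4-difluorophenyl would read at this place. Going by these compounds, it also remains open whether 2,4-dichlorophenyl gives a step of similar size in the thiourea series of compound 1.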